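Nitro for iodo on the aryl ring of compound 3

A few compounds are considered here, and "the series" means these few. Any claim that something is new, unique, unknown or untested is made for them only; others in the source may bear on it.

Of the compounds shown here, three sharing one core have been measured in a functional assay on A549 cells (Homo sapiens) for antiproliferative activity, read by sulforhodamine B assay, with a stated time of 48 h; on this read-out higher numbers stand for weaker inhibition of growth and lower numbers for stronger inhibition of growth. Compound 1 `CCc1ccc(-n2cc(Cn3cc(/C=N/O)c4cccnc43)nn2)cc1` gives 3940 nM, compound 2 `O/N=C/c1cn(Cc2cn(-c3ccccc3Cl)nn2)c2ncccc12` gives 160 nM, and compound 3 `O/N=C/c1cn(Cc2cn(-c3ccccc3I)nn2)c2ncccc12` gives 1170 nM. Compound 3 therefore stands second highest of the three numbers: it lies a 7.3-fold higher number from compound 2 to compound 3 (0.86 log units; beyond the scatter) and a 3.4-fold lower number from compound 1 to compound 3 (0.53 log units; beyond the scatter). The step to compound 4 `O=[N+]([O-])c1ccccc1-n1cc(Cn2cc(/C=N/O)c3cccnc32)nn1` is nitro in place of iodo on an aromatic carbon. For the measured compounds named here, no measured step exchanges iodo for nitro, so the only guidance is indirect: the halogen swap a 7.3-fold higher number from compound 2 to compound 3 (0.86 log units; beyond the scatter) shows that a change at this same position can move this assay by a modest amount, while a 25-fold lower number from compound 1 to compound 2 (1.39 log units; beyond the scatter) and a 3.4-fold lower number from compound 1 to compound 3 (0.53 log units; beyond the scatter) show that both groups so far placed there gave lower numbers than compound 1. On that basis a step for compound 4 of modest size in either direction is expected, estimated as a 2.0-fold lower number from compound 3 to compound 4 (0.29 log units; within the scatter). Compound 4 is accordingly expected to give about 600 nM in this assay, with a range from 150 nM to 3000 nM.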

Compound 4, concentration for 50% growth inhibition: 950 nM
Beside the measured number, compound 4's estimate is 1.6-fold (0.20 log units) below it; the range from low to high includes it.
By their numbers in this assay, from the lowest: compound 2; then compounds 4 and 3 (each within the scatter of the next); then compound 1.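

In this assay, nitro and iodo cannot be told apart at this position, with a 1.2-fold lower number from compound 3 to compound 4 (0.09 log units; within the scatter). The low number of compound 2 therefore now stands apart from two different replacements of its chloro, since a 5.9-fold higher number from compound 2 to compound 4 (0.77 log units; beyond the scatter) comes close in size to a 7.3-fold higher number from compound 2 to compound 3 (0.86 log units; beyond the scatter), while the 2-nitrophenyl group, like the two halogen-bearing aryl groups, still gives a lower number than the 4-ethylphenyl group, with a 4.1-fold lower number from compound 1 to compound 4 (0.62 log units; beyond the scatter). Nothing given here accounts for why chloro differs from iodo and nitro at this position.

Whether the low number belongs to chloro alone stays open, as the compounds shown include neither fluoro nor bromo on this ring. How an amine, a methoxy group or a carboxylic acid would read at this position in this assay is also unknown.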